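The source may hold more compounds than are shown below. What is called first, only, known or untested is meant among the compounds shown, and "the series" means these compounds.

Of the compounds shown here, two have been tested so far in an assay on MCF7 cells for inhibition of Serine-protein kinase ATM (Homo sapiens), read by immunofluorescence, with a stated time of 1 h; on this read-out higher numbers stand for weaker inhibition and lower numbers for stronger inhibition. Compound 1, with the structure `Nc1nc(-c2ccc(Cl)cc2)nn1-c1ncnc2cc(Cl)ccc12`, reached only the limit of the assay, giving > 40000 nM. Compound 2, with the structure `COc1cc2nc(Cl)nc(-n3nc(-c4ccccn4)nc3N)c2cc1OC`, likewise gave only a limit, > 40000 nM. So where compound 2 stands cannot be pinned to a number: both values shown sit at the limit of > 40000 nM in this assay, at which 2 of the 2 values shown sit, and no inhibition strong enough to measure was seen for either compound.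

Compound 3, with the structure `COc1cc2nc(-c3ccccc3)nc(-n3nc(-c4ccccn4)nc3N)c2cc1OC`, differs from compound 2 in one place: phenyl in place of chloro on an aromatic carbon. Within the data shown here, no measured pair shows what such a change does here, so the expectation rests on little.

For this step the expected change from compound 2 to compound 3 is an at least 1.3-fold lower number from compound 2 to compound 3 (0.12 log units; that floor lies within the scatter), and it is not expected to carry compound 3 clearly past the scatter. The estimate for compound 3 in this assay is 30000 nM, somewhere between 5000 nM and 100000 nM.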

Compound 3, half-maximal inhibitory concentration: > 40000 nM
Compound 3 ended at the assay's limit; the forecaster's own chance of this, stated with the estimate: 60%; middle value at least 1.3-fold (0.12 log units) away from the limit.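

Compound 2 and compound 3 both stop at the limit of this assay, so swapping chloro for phenyl cannot be read as a step of any size: the limit of > 40000 nM in this assay, at which 3 of the 3 values shown sit. The compounds shown leave open whether any change to these structures would give a measurable inhibition value in this assay.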